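A few compounds are considered here, and "the series" means these few. Any claim that something is new, unique, unknown or untested is made for them only; others in the source may bear on it.

Compound 1 `CC(C)[C@H](NC(=O)COc1cccc2ccccc12)C(=O)N[C@@H](CC(=O)O)C(=O)COC(=O)c1c(Cl)cccc1Cl`: 10600 nM
Compound 2 `CC(C)[C@H](NC(=O)COc1cccc2ccccc12)C(=O)N[C@@H](CC(=O)O)C(=O)COc1ccc(-c2ccccc2)cc1`: 87900 nM

In a functional assay on Jurkat cells (Homo sapiens) (on this read-out lower numbers stand for stronger inhibition and higher numbers for weaker inhibition), compound 2 gives 87900 nM, the higher of the two numbers and beyond the scatter from compound 1. Compound 3 `CC(C)[C@H](NC(=O)COc1cccc2ccccc12)C(=O)N[C@@H](CC(=O)O)C(=O)COc1ccc(C(N)=O)cc1` keeps the shared core of compound 2 and carries one change: carbamoyl in place of phenyl on an aromatic carbon. In words, carbamoyl stands in place of phenyl on an aromatic carbon. Among the measured compounds shown here, only one measured step bears on this, an 8.3-fold higher number from compound 1 to compound 2 (0.92 log units; beyond the scatter), a modest step beyond the scatter that came with 4-phenylphenyl in place of (2,6-dichlorophenyl)carbonyl on an oxygen on a saturated carbon. For the measured compounds named here, no measured pair tests the carbamoyl group itself, so that step serves only as a rough guide to size. A modest move toward a lower number is expected, smaller than that measured step. The expected change is a 2.2-fold lower number from compound 2 to compound 3 (0.34 log units; beyond the scatter). For compound 3 the estimated value is 40000 nM, with an expected range of 12000 nM to 130000 nM.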

Compound 3, half-maximal inhibitory concentration: > 100000 nM
Compound 3: only a limit was reported; the forecaster's own chance of this, stated with the estimate: 15%; at least 2.5-fold (0.39 log units) between middle value and limit.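

In this assay compound 3 gives only a limit of the assay, not a number: the limit of > 100000 nM in this assay, at which 1 of the 3 values shown sits. Carbamoyl in place of phenyl on this aromatic carbon therefore brought no reading of stronger inhibition, yet the step (an at least 1.1-fold higher number from compound 2 to compound 3 (0.05 log units; that floor lies within the scatter)) gives only a floor, which leaves the size and order of the two compounds unsettled. Against compound 1 the picture is firmer: 4-carbamoylphenyl on the oxygen (an at least 9.4-fold higher number from compound 1 to compound 3 (0.97 log units; beyond the scatter)) lands on the weak side, as 4-phenylphenyl did (an 8.3-fold higher number from compound 1 to compound 2 (0.92 log units; beyond the scatter)), so neither group matches the (2,6-dichlorophenyl)carbonyl group.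

The compounds shown leave open how far compound 3 lies past its limit. They also leave open whether a methoxy group, an amine or a carboxylic acid on this aromatic carbon, para to a large group, would give a lower number.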